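The compounds below may be only part of what the source reports. "The series", "measured", "known", "first", "only" and "open" are said of these compounds alone.

Measured compounds:
- compound 1, `Cc1ccc(C(=O)Nc2nc(Cl)c3cn(C)nc3n2)cc1`: 13500 nM
- compound 2, `CC(C)n1cc2c(Cl)nc(NC(=O)c3ccccc3)nc2n1`: 12800 nM

Both values come from an assay on CHO cells for displacement of a labelled ligand from adenosine receptor A3 (Homo sapiens), read by scintillation counting, with a stated time of 3 h; on this read-out higher numbers stand for weaker inhibition and lower numbers for stronger inhibition. In this assay compound 1 gives 13500 nM and compound 2 gives 12800 nM, and the two numbers lie within the usual scatter of each other, so the data cannot tell the two compounds apart. Both are weak binders on this read-out.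

Compound 3, `Cc1ccc(C(=O)Nc2nc(Cl)c3cn(C(C)C)nc3n2)cc1`, has not yet been measured. It differs from compound 2 in one place: methyl in place of hydrogen on an aromatic carbon. Compound 1 already carries this same methyl on the same ring with a different group on the shared core, and shows a value within the scatter of compound 2, so no step beyond the scatter is expected here in either direction. Compound 3 is therefore estimated at 13000 nM, with a range from 6000 nM to 30000 nM, meaning an expected step of a 1.0-fold higher number from compound 2 to compound 3 (0.01 log units; within the scatter).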

Compound 3, inhibition constant: > 100000 nM
Compound 3: a limit, no number; the forecaster's own chance of this, stated with the estimate: 10%; middle value at least 7.6-fold (0.88 log units) away from the limit.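

The value for compound 3 is a limit of the assay, not a number: the limit of > 100000 nM in this assay, at which 1 of the 3 values shown sits.

In this assay, going from phenyl to 4-methylphenyl with the isopropyl in place gives an at least 7.8-fold higher number from compound 2 to compound 3 (0.89 log units; beyond the scatter), and going from methyl to isopropyl on the aromatic nitrogen with the 4-methylphenyl in place gives an at least 7.4-fold higher number from compound 1 to compound 3 (0.86 log units; beyond the scatter). So this one added methyl is not a neutral change on this core, and compound 3, which carries both the 4-methylphenyl and the isopropyl, binds more weakly than either compound that differs from it in one of those two places.

From the compounds shown here alone, how far the true value of compound 3 lies beyond the limit stays open. Also open, going by these compounds, is whether ethyl on the aromatic nitrogen, or a fluorine or methoxy in place of the methyl on the phenyl ring, would give a smaller step.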